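This account rests on a few compounds, and the source may have more. Where it says the series, first, only, none or still open, it means among the compounds named here.

The series shares one core, seen in compound 1 `COc1ccc(-c2cc(/C=C/C(=O)c3cc(OC)c(OC)c(OC)c3)[nH]n2)cc1OC`, compound 2 `COc1ccc(C(=O)/C=C/c2cc(-c3cc(OC)c(OC)c(OC)c3)n[nH]2)cc1` and compound 3 `COc1ccc(C(=O)/C=C/c2cc(-c3cc(OC)c(OC)c(OC)c3)n[nH]2)cc1OC`. In a functional assay on NCI-H226 cells (Homo sapiens) for cytotoxicity, read by sulforhodamine B assay, with a stated time of 48 h, tested at 0.01 uM (on this read-out lower numbers stand for a stronger effect and higher numbers for a weaker effect at the one concentration tested), compound 1 gives 93%, compound 2 gives 99% and compound 3 gives 98%. All three numbers lie within the usual scatter of one another, so compound 3 cannot be set apart from either neighbour on this read-out; its nearest number is that of compound 2 and its furthest that of compound 1, and both gaps are within the scatter.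

Compound 4 `COc1cc(C(=O)/C=C/c2cc(-c3cc(OC)c(OC)c(OC)c3)n[nH]2)cc(OC)c1OC` differs from compound 3 in one place: methoxy in place of hydrogen on an aromatic carbon.

Among the compounds with values here, one measured step bears on this change. The same kind of change, a methoxy in place of hydrogen on an aromatic carbon, gave a number 1 percentage points lower from compound 2 to compound 3 (within the scatter), a step within the scatter. On that basis no step beyond the scatter is expected from compound 3 to compound 4 in this assay, and the estimated step is a number 1 percentage points lower from compound 3 to compound 4 (within the scatter). Compound 4 is therefore expected to give about 97% in this assay, with a likely range from 88% to 104%.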

Compound 4, a percentage reported as activity, at one concentration (the size of the read-out at that concentration, not a potency): 99%
Estimate against measurement, compound 4: 2 percentage points below; the range from low to high includes it.
By their numbers in this assay, from the lowest: compounds 1, 3, 2 and 4 (each within the scatter of the next).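

In this assay, methoxy in place of hydrogen at this position, ortho to a methoxy group and meta to a large group, gave a number 1 percentage points higher from compound 3 to compound 4 (within the scatter), so the position takes this group with no step beyond the scatter. The same change at a second place, read on the core of compound 1, gave a number 6 percentage points higher from compound 1 to compound 4 (within the scatter), which is also no step beyond the scatter, so the earlier single step on this change now has two companions. The steps on the two cores also cannot be told apart, which means that this change reads alike on both within the limits of this read-out: the same change on two cores in this assay, a number 1 percentage points lower (within the scatter) from compound 2 to compound 3 and a number 6 percentage points higher (within the scatter) from compound 1 to compound 4, 7 percentage points apart, within the scatter of two such steps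

The compounds shown leave open whether a different group at this position, such as an amine, a hydroxyl or a carboxylic acid, would give a step beyond the scatter in this assay. As every number here comes from the one concentration tested and lies within the scatter of the next, they also leave open whether methoxy in place of hydrogen would make any difference at another concentration.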